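The source may hold more compounds than are shown below. What is called first, only, known or untested is meant among the compounds shown, and "the series" means these compounds.

Measured compounds and their values:
- Compound 1, `Cn1ncc(Cl)c1-c1cc(C(=O)N[C@@H]2CN[C@H](CCN3CCC(O)CC3)C[C@H]2c2ccc(Cl)c(Cl)c2)oc1Cl`: in an assay for inhibition of RAC-alpha serine/threonine-protein kinase (Homo sapiens), read by HTRF, with a stated time of 1 h (a higher number here means a weaker inhibitor, a lower number a stronger inhibitor), compound 1 gives 5.99 nM.
- Compound 2, `Cn1ncc(Cl)c1-c1cc(C(=O)N[C@@H]2CN[C@H](CC(N)=O)C[C@H]2c2ccc(Cl)c(Cl)c2)oc1Cl`: in this assay compound 2 gives 3.24 nM.
- Compound 3, `C=CC[C@@H]1C[C@@H](c2ccc(Cl)c(Cl)c2)[C@H](NC(=O)c2cc(-c3c(Cl)cnn3C)c(Cl)o2)CN1`: in this assay compound 3 gives 12.4 nM.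

Of these three, compound 3 carries the highest number, and so is the weakest inhibitor among them: the steps of a 2.1-fold higher number from compound 1 to compound 3 (0.32 log units; beyond the scatter) and a 3.8-fold higher number from compound 2 to compound 3 (0.58 log units; beyond the scatter) are both beyond the scatter but modest in size.

Compound 4, `CCC[C@@H]1C[C@@H](c2ccc(Cl)c(Cl)c2)[C@H](NC(=O)c2cc(-c3c(Cl)cnn3C)c(Cl)o2)CN1`, differs from compound 3 in one place: ethyl in place of vinyl on a saturated chain carbon bound to a saturated ring carbon. Within the data shown here, the three measured steps all replace the group at this same position, but none of them exchanges vinyl for ethyl, so no measured step bears directly on this change. What the measured steps do show is that swapping groups at this position moved the numbers only modestly, as in a 1.8-fold lower number from compound 1 to compound 2 (0.27 log units; within the scatter), a 2.1-fold higher number from compound 1 to compound 3 (0.32 log units; beyond the scatter) and a 3.8-fold higher number from compound 2 to compound 3 (0.58 log units; beyond the scatter). Since vinyl and ethyl share the same count of heavy atoms and differ only in the double bond, the expected step is small, and its direction cannot be told from the data: the estimate is a 1.0-fold lower number from compound 3 to compound 4 (0.01 log units; within the scatter), with no clear movement beyond the scatter. Compound 4 is therefore expected to give about 12 nM in this assay, within a range from 5 nM to 30 nM.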

Compound 4, half-maximal inhibitory concentration: 10.4 nM
The estimate for compound 4 lay 1.2-fold (0.06 log units) above the measured number; the measured number falls inside the stated range.
By their numbers in this assay, from the lowest: compounds 2, 1, 4 and 3 (each within the scatter of the next, the first and the last beyond it).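

Among these compounds, removing the double bond leaves no readable difference: the step of a 1.2-fold lower number from compound 3 to compound 4 (0.08 log units; within the scatter) is the first direct comparison of vinyl with ethyl on this saturated chain carbon, and in this assay the two groups cannot be told apart. The step of a 1.7-fold higher number from compound 1 to compound 4 (0.24 log units; within the scatter) likewise stays within the scatter, so a methyl in place of 4-hydroxypiperidin-1-yl on the chain gives no clear separation, while the step of a 3.2-fold higher number from compound 2 to compound 4 (0.51 log units; beyond the scatter) sets carbamoyl apart from ethyl, though only modestly. Nothing available here explains any of these steps.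

The compounds shown leave open how a longer chain such as butyl, or a chain carrying a primary amine or a carboxylic acid, would read in this assay at this position. They also leave open whether the close agreement between vinyl and ethyl would hold if another part of the shared core were changed, since all four compounds keep that core the same.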